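This account rests on a few compounds, and the source may have more. Where it says the series, first, only, none or still open, it means among the compounds named here.

Of the compounds shown here, three sharing one core have been measured in an assay on HEK293 cells for positive allosteric modulation of metabotropic glutamate receptor 2 (Rattus norvegicus), read by thallium flux, with a stated time of 2.5 min; on this read-out lower numbers stand for smaller maximal responses and higher numbers for larger maximal responses. Compound 1 `Cc1c(OCCCCOc2ccccc2C(=O)O)ccc(C(=O)CC(C)C)c1O` gives 92.4%. Compound 2 `Cc1c(OCCCCOc2ccc(F)c(C(=O)O)c2)ccc(C(=O)CC2CCCC2)c1O` gives 81%. Compound 3 `CC(=O)c1ccc(OCCCCOc2ccc(F)c(C(=O)O)c2)c(C)c1O` gives 75.5%, the lowest of the three numbers; its nearest neighbour is compound 2, a gap within the usual scatter, while compound 1 stands further away, beyond the scatter.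

Compound 4 `Cc1c(OCCCCOc2ccc(F)c(C(=O)O)c2)ccc(C(=O)CC(C)C)c1O` has not yet been measured. Compared with compound 3 it carries isopropyl in place of hydrogen on a saturated chain carbon bound to a carbonyl carbon. Among the compounds with values here, one measured step bears on this change: a number 5.5 percentage points lower from compound 2 to compound 3 (within the scatter), where hydrogen replaced cyclopentyl on a saturated chain carbon bound to a carbonyl carbon, a shift that stayed within the scatter. Placing an isopropyl at the same position is a change of the opposite kind, so in this assay a small rise, or none beyond the scatter, is expected. Compound 1, which also carries an isobutylcarbonyl, gives the highest number of the three, but it differs from compound 4 elsewhere as well, so it offers only a weak hint. For compound 4 the expected maximal response is 81%, with a range from 66% to 96%. The estimated step is a number 5.5 percentage points higher from compound 3 to compound 4 (within the scatter).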

Compound 4, largest response reached (reported as percent of maximum), in percent of the reference or control that the assay uses: 84.5%
Estimate against measurement, compound 4: 3.5 percentage points below; low and high end bracket the measured number.
By their numbers in this assay, from the lowest: compounds 3, 2, 4 and 1 (each within the scatter of the next, the first and the last beyond it).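

In this assay, placing isopropyl on the saturated chain carbon bound to the carbonyl carbon, which turns acetyl into isobutylcarbonyl, gives a number 9 percentage points higher from compound 3 to compound 4 (within the scatter) and adds a second measured change at this position to the one seen earlier. Within the data shown here, exchanging cyclopentyl for isopropyl at the same place gives a number 3.5 percentage points higher from compound 2 to compound 4 (within the scatter), so hydrogen, isopropyl and cyclopentyl have now been compared directly here, and no step among them leaves the scatter of this read-out. The change at the other end of the molecule, 3-carboxy-4-fluorophenyl in place of 2-carboxyphenyl on an oxygen on a saturated carbon, gives a number 7.9 percentage points lower from compound 1 to compound 4 (within the scatter), so this swap of the acid-bearing ring, read on an isobutylcarbonyl background, also stays within the scatter.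

The compounds shown leave open whether an amine, a hydroxyl group or a longer chain at the saturated chain carbon would carry the maximal response beyond the scatter, rather than the carbon-only groups compared so far. No measurement at hand offers an explanation for any of these numbers.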